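A Larger Amide Group Tested Against a Silent Series

This account rests on a few compounds, and the source may have more. Where it says the series, first, only, none or still open, it means among the compounds named here.

Three compounds of this series were examined in an assay on HEK293 cells for positive allosteric modulation of metabotropic glutamate receptor 5 (Homo sapiens), read by FLIPR, with a stated time of 1 h; a higher number here means that more compound is needed for the effect, a lower number that less compound is needed. Compound 1, `Cc1cccc(C#Cc2nc3c(s2)C(=O)NCC3)c1`, gives only a limit of the assay, > 10000 nM. Compound 2, `Fc1cccc(C#Cc2nc3c(s2)CN(C2CCC2)CC3)c1`, likewise returns a limit, > 10000 nM. Compound 3, `CCC(=O)N1CCc2nc(C#Cc3ccccc3)sc2C1`, stands at a limit as well, > 10000 nM, so no number is known for it; its standing among the values shown is described by the limit of > 10000 nM in this assay, at which 3 of the 3 values shown sit. For the measured compounds named here, no step between measured compounds is available, since no two of them differ in one place.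

Compound 4, `O=C(C1CCOCC1)N1CCc2nc(C#Cc3ccccc3)sc2C1`, differs from compound 3 in one place: oxan-4-yl in place of ethyl on a carbonyl carbon. Cut one bond further out, the change reads propanoyl to (oxan-4-yl)carbonyl, on a carbonyl carbon whose other neighbour is an amide-type nitrogen in a ring. With every measured value resting at a limit in this assay, the account expects no step beyond the usual scatter, an expectation written as a step that the limit leaves unreadable from compound 3 to compound 4. Compound 4 is therefore estimated at 20000 nM, within a range from 5000 nM to 80000 nM, and it is expected that the assay will most likely again report only a limit.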

Compound 4, half-maximal effective concentration: 290 nM
For compound 4 the middle estimate is 69-fold (1.84 log units) above the measured one, outside the stated range (below it).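

In this assay, for the compounds shown here, the change to oxan-4-yl in place of ethyl on a carbonyl carbon gives an at least 34-fold lower number from compound 3 to compound 4 (1.53 log units; beyond the scatter), and compound 4 carries the only true number in this set. The earlier compounds shown here could not show that this place, on a carbonyl carbon whose other neighbour is an amide-type nitrogen in a ring, can carry the series out of the limit. Before compound 4 no value could be read at all, and even now most of the values remain at that limit: the limit of > 10000 nM in this assay, at which 3 of the 4 values shown sit.

As far as these compounds go, compound 3 gives > 10000 nM, which is a limit and not a number, so the full size of the step stays open. Also open, from the compounds shown here alone, is whether the ring or its oxygen matters, and what a cyclohexyl group or a longer chain such as butanoyl on the same carbonyl carbon would give.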